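The source may hold more compounds than are shown below. What is called first, only, known or untested is meant among the compounds shown, and "the series" means these compounds.

Compound 1 `CC(C)c1ccccc1OS(=O)(=O)c1cccc(NC(=O)CCCl)c1` and compound 2 `CC(=O)Nc1ccc(S(=O)(=O)Oc2ccccc2I)cc1` are the two measured compounds.

In a functional assay on M21 cells (Homo sapiens) for antiproliferative activity, read by sulforhodamine B assay, with a stated time of 48 h (a higher number here means a weaker inhibitor, a lower number a stronger inhibitor), compound 1 gives > 40000 nM, which is a limit of the assay rather than a number (the limit of > 40000 nM in this assay, at which 1 of the 2 values shown sits). In this assay, among the compounds with values here, compound 2 gives 27000 nM, the only true number in the set, so it stands as the sole point of reference. Compound 3 `CCC(=O)Nc1ccc(S(=O)(=O)Oc2ccccc2I)cc1` differs from compound 2 by methyl in place of hydrogen on a saturated chain carbon bound to a carbonyl carbon. Within the data shown here, no measured step covers such a change, so nothing beyond the usual scatter is expected in this assay. The step from compound 2 to compound 3 is expected to be no change at the digits printed from compound 2 to compound 3 (within the scatter). Compound 3 is estimated at 27000 nM, with a range of 10000 nM to 60000 nM.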

Compound 3, half-maximal inhibitory concentration: 11000 nM
Compound 3: middle estimate off by 2.5-fold (0.39 log units), on the high side, within the range that was stated.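

In this assay, going from acetamido to propanoylamino gives a 2.5-fold lower number from compound 2 to compound 3 (0.39 log units; beyond the scatter), so a single added methyl on this saturated chain carbon bound to a carbonyl carbon is enough to move the read-out. The earlier compounds shown here offered no comparison of this kind, with a change in one place only. Nothing shown here gives a reason for the step.

On these data alone, whether a longer chain such as butanoyl would lower the number further remains open, as does the effect of an amine or a carboxylic acid on this carbon. A single step shows one direction, not yet a trend.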